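Working notes: butyl to but-1-en-1-yl on the chain

The source may hold more compounds than are shown below. What is called first, only, known or untested is meant among the compounds shown, and "the series" means these compounds.

In a functional assay on MCF7 cells (Homo sapiens) for antiproliferative activity, read by MTT assay (on this read-out lower numbers stand for stronger inhibition and higher numbers for weaker inhibition), compound 1 (`CCCC/C=C\CCCCCCCCCc1cc(=O)c2c(O)cc(O)c(C)c2o1`) gives 17500 nM, compound 2 (`CC/C=C\C/C=C\C/C=C\CCCCCCCc1cc(=O)c2c(O)cc(O)cc2o1`) gives 17500 nM and compound 3 (`CCCCC/C=C\C/C=C\CCCCCCCc1cc(=O)c2c(O)cc(O)c(C)c2o1`) gives 17500 nM. Within the data shown here, compound 3 thus stands level with compounds 1 and 2 at the digits reported, and no member of this small set separates from the others.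

The next structure is compound 4 (`CC/C=C\C/C=C\C/C=C\CCCCCCCc1cc(=O)c2c(O)cc(O)c(C)c2o1`), which carries but-1-en-1-yl in place of butyl on a saturated chain carbon bound to a double-bonded chain carbon.

Among the measured compounds shown here, only one measured step between close neighbours bears on this change. It is no change at the digits printed from compound 1 to compound 3 (within the scatter), with deca-1,4-dien-1-yl in place of oct-3-en-1-yl on a saturated chain carbon, seven bonds along the chain from an aromatic carbon. That step is also a change within the chain, and it stays within the scatter. The data hold no chain change that moves the value, so no direction can be favoured, and a step in this assay beyond the scatter is not expected.

The estimated step is no change at the digits printed from compound 3 to compound 4 (within the scatter). Compound 4 is expected to give 17500 nM, with an estimated range of 10000 nM to 30000 nM.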

Compound 4, half-maximal inhibitory concentration: 17500 nM
Compound 4: middle estimate and measured number agree at the digits printed; the measured number falls inside the stated range.
By their numbers in this assay, from the lowest: compounds 1, 2, 3 and 4 (each within the scatter of the next).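

In this assay, but-1-en-1-yl in place of butyl on a saturated chain carbon bound to a double-bonded chain carbon gives no change at the digits printed from compound 3 to compound 4 (within the scatter) and so adds a change at this place in the chain that stays within the scatter. Among these compounds, compound 4 also gives the only step in the set outside the chain, as methyl in place of hydrogen on an aromatic carbon gives no change at the digits printed from compound 2 to compound 4 (within the scatter) and the chain step of a group of 10 heavy atoms in place of a group of 8 heavy atoms, on a saturated chain carbon seven bonds along the chain from an aromatic carbon, gives no change at the digits printed from compound 1 to compound 4 (within the scatter) with the same outcome. The data offer no separate measurement that could account for this flat reading.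

As far as these compounds go, whether a much shorter chain, or an amine or a carboxylic acid at the far end of the chain, would move the value remains open. Among the compounds shown here, also open is whether methyl in place of hydrogen on the aromatic carbon would read the same with chains other than the one shared by compound 2 and compound 4.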